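A few compounds are considered here, and "the series" means these few. Any claim that something is new, unique, unknown or untested is made for them only; others in the source may bear on it.

Measured compounds:
compound 1 `O=C1N/C(=N/c2csc(-c3ccc(Cl)cc3)c2)S/C1=C\c1ccc2ccccc2c1`, a functional assay on MCF7 cells (Homo sapiens) for cytotoxicity, read by MTT assay, with a stated time of 72 h (on this read-out lower numbers stand for stronger inhibition and higher numbers for weaker inhibition), 1200 nM
compound 2 `COc1ccc(/C=C2\S/C(=N\c3csc(-c4ccc(Cl)cc4)c3)NC2=O)cc1OC`, compound 2 in this assay 7600 nM
compound 3 `Cc1ccc(/C=C2\S/C(=N\c3nc(-c4ccc(Cl)cc4)cs3)NC2=O)cc1`, compound 3 in this assay 400 nM

Compound 3 gives the lowest number of the three in this assay; its nearest neighbour is compound 1 and the furthest is compound 2, both steps beyond the scatter. Compound 4 `O=C1N/C(=N/c2nc(-c3ccc(Cl)cc3)cs2)S/C1=C\c1ccc(F)cc1` is not yet measured; it differs from compound 3 by fluoro in place of methyl on an aromatic carbon, that is, 4-methylphenyl to 4-fluorophenyl.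

Going by the values given here, the only step between compounds differing in one place is a 6.3-fold higher number from compound 1 to compound 2 (0.80 log units; beyond the scatter), which swaps the whole aryl group at the same chain position and sits on a different core from compound 3, so it does not bear directly on the methyl-to-fluoro exchange. Among the compounds with values here, no measured pair isolates a small substituent change at this position. Compound 4 is therefore expected to stay close to compound 3, with the step of a 1.5-fold higher number from compound 3 to compound 4 (0.18 log units; within the scatter) likely within the scatter, a small drift toward a higher number being as plausible as none. The estimate for compound 4 in this assay is 600 nM, in the range 250 nM to 1500 nM.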

Compound 4, half-maximal inhibitory concentration: > 50000 nM
Compound 4 ended at the assay's limit (the forecaster's own chance of this, stated with the estimate: 3%); middle value at least 83-fold (1.92 log units) from the limit.
By their numbers in this assay, from the lowest: compound 3; then compound 1; then compound 2. At a limit, above all of these: compound 4.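

In this assay the exchange of methyl for fluoro, one heavy atom for one heavy atom with no hydrogen-bond donor or acceptor counted on either side, gives an at least 120-fold higher number from compound 3 to compound 4 (2.09 log units; beyond the scatter). Going by these compounds alone, the only earlier step, a 6.3-fold higher number from compound 1 to compound 2 (0.80 log units; beyond the scatter), swapped a whole aryl group on a different core; the new step shows that a single-atom change on the aromatic carbon para to a large group can outweigh that swap. The value of compound 4 is a limit and not a number: the limit of > 50000 nM in this assay, at which 1 of the 4 values shown sits.

From the compounds shown here alone, whether an amine or a longer chain such as ethyl on this carbon would behave like methyl or like fluoro stays open. Also open, going by these compounds, is whether the same exchange on the core of compound 1 would give a step of this size.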